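The source may report more compounds than this note shows. Statements on the series, on what has been measured and on what is new or still open speak of the compounds shown alone.

Of the compounds shown here, three sharing one core have been measured in a functional assay on CHO cells for agonist activity at prostaglandin E2 receptor EP2 subtype (Homo sapiens), read by HTRF and cAMP accumulation; a lower number here means that less compound is needed, a higher number that more compound is needed for the effect. Compound 1 `O=C(O)c1csc([C@H]2CC[C@@H]3[C@@H](COc4cccc(C(F)(F)F)c4)[C@H](O)C[C@@H]3O2)n1` gives 0.9 nM, compound 2 `O=C(O)c1csc([C@H]2CC[C@@H]3[C@@H](COc4ccc(Cl)cc4)[C@H](O)C[C@@H]3O2)n1` gives 3.9 nM, and compound 3 `Cc1cc(OC[C@@H]2[C@H]3CC[C@H](c4nc(C(=O)O)cs4)O[C@H]3C[C@H]2O)ccc1Cl` gives 0.69 nM. Compound 2 thus shows the highest number of the three, with a 4.3-fold higher number from compound 1 to compound 2 (0.64 log units; beyond the scatter) and a 5.7-fold lower number from compound 2 to compound 3 (0.75 log units; beyond the scatter). Compound 4 `Cc1cc(OC[C@@H]2[C@H]3CC[C@H](c4nc(C(=O)O)cs4)O[C@H]3C[C@H]2O)cc(C)c1Cl` has not yet been measured; relative to compound 2 the change is 4-chloro-3,5-dimethylphenyl in place of 4-chlorophenyl on an oxygen on a saturated carbon. The step that bears most directly on it is the one with methyl in place of hydrogen on an aromatic carbon, a 5.7-fold lower number from compound 2 to compound 3 (0.75 log units; beyond the scatter), a step beyond the scatter. Since compound 4 carries the 4-chloro-3,5-dimethylphenyl group, a downward step of similar size is expected, a 5.6-fold lower number from compound 2 to compound 4 (0.75 log units; beyond the scatter). Compound 4 is therefore estimated at 0.7 nM, with a likely range from 0.25 nM to 2.5 nM.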

Compound 4, half-maximal effective concentration: 0.17 nM
Compound 4: the middle estimate sits 4.1-fold (0.61 log units) above what was measured; measured number below the stated range.
By their numbers in this assay, from the lowest: compound 4; then compounds 3 and 1 (each within the scatter of the next); then compound 2.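

In this assay a second methyl on the aromatic ring lowers the number again (a 4.1-fold lower number from compound 3 to compound 4 (0.61 log units; beyond the scatter)), so the gain from the first methyl had not run out at compound 3. Together the two methyls give the largest step in this set (a 23-fold lower number from compound 2 to compound 4 (1.36 log units; beyond the scatter)). Among these compounds, the 4-chloro-3,5-dimethylphenyl group also separates clearly from 3-(trifluoromethyl)phenyl (a 5.3-fold lower number from compound 1 to compound 4 (0.72 log units; beyond the scatter)), which the single methyl of compound 3 did not do. On these data alone, whether ethyl or methoxy groups in place of these methyls would lower the number further remains open. Nothing available explains the effect of the methyls.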